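Phenyl for thiophen-2-yl in a series held at its limit

This account rests on a few compounds, and the source may have more. Where it says the series, first, only, none or still open, it means among the compounds named here.

Compound 1 `COc1ncnc2c1c(-c1ccccc1)cn2[C@@H]1O[C@H](CO)[C@@H](O)[C@H]1O` gives > 20000 nM as a limit
Compound 2 `COc1nc(N)nc2c1c(-c1ccco1)cn2[C@@H]1O[C@H](CO)[C@@H](O)[C@H]1O` gives > 20000 nM as a limit
Compound 3 `COc1nc(N)nc2c1c(-c1cccs1)cn2[C@@H]1O[C@H](CO)[C@@H](O)[C@H]1O` gives > 20000 nM as a limit

In a functional assay on HeLa S3 cells (Homo sapiens) for antiproliferative activity, read by XTT assay, with a stated time of 72 h (a lower number here means a stronger inhibitor, a higher number a weaker inhibitor), compound 3 gives > 20000 nM and this is a limit, not a number. Among the measured compounds shown here, the whole set stands in the same place, with the limit of > 20000 nM in this assay, at which 3 of the 3 values shown sit, as its only reading so far. Compound 4 `COc1nc(N)nc2c1c(-c1ccccc1)cn2[C@@H]1O[C@H](CO)[C@@H](O)[C@H]1O` has not yet been measured. Its difference from compound 3 is phenyl in place of thiophen-2-yl on an aromatic carbon and amounts to phenyl in place of thiophen-2-yl on an aromatic carbon. For the measured compounds named here, the one measured step of a similar kind is a step that the two limits leave unreadable from compound 2 to compound 3 and it offers no size to carry over. Compound 1 also bears phenyl and gives > 20000 nM as a limit. No readable step points in either direction, so no change beyond the scatter is expected in this assay here. The expected step of a number no higher from compound 3 to compound 4 (the limit leaves the size open) is only an estimate. For this assay compound 4 is expected at 20000 nM with an estimated range from 10000 nM to 40000 nM and most likely only a limit will be reported.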

Compound 4, half-maximal inhibitory concentration: > 20000 nM
Compound 4 ended at the assay's limit (the forecaster's own chance of this, stated with the estimate: 85%); the middle value lies on the limit itself.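

Compound 4 joins compound 1, compound 2 and compound 3 at one limit, so no new step can be read among them: the limit of > 20000 nM in this assay, at which 4 of the 4 values shown sit.

The compounds shown leave open how these four truly compare in this assay, and which change, if any, would give a measurable value.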